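From trifluoromethyl to phenyl in a cell tolerance test

The source may hold more compounds than are shown below. What is called first, only, known or untested is meant among the compounds shown, and "the series" means these compounds.

Compound 1 `CC(C)(C)c1ccc(-c2c[nH]cc2C(c2ccc(Cl)cc2Cl)n2ccnc2)cc1`: 22900 nM
Compound 2 `CSc1ccc(-c2c[nH]cc2C(c2ccc(Cl)cc2Cl)n2ccnc2)cc1`: 7220 nM
Compound 3 `FC(F)(F)c1ccc(-c2c[nH]cc2C(c2ccc(Cl)cc2Cl)n2ccnc2)cc1`: 9400 nM

All three values come from an ADME assay on L6 cells (Rattus norvegicus) for cytotoxicity, read by fluorescence and resazurin assay, with a stated time of 72 h; a lower number here means that less compound is tolerated, a higher number that more compound is tolerated. Compound 3 stands clearly apart from compound 1, as a 2.4-fold lower number from compound 1 to compound 3 (0.39 log units; beyond the scatter) shows. It is on a par with compound 2, as a 1.3-fold higher number from compound 2 to compound 3 (0.11 log units; within the scatter) shows.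

Compound 4 `Clc1ccc(C(c2c[nH]cc2-c2ccc(-c3ccccc3)cc2)n2ccnc2)c(Cl)c1` keeps the rest of compound 3 and changes one group: phenyl in place of trifluoromethyl on an aromatic carbon. Among the measured compounds shown here, no measured compound carries phenyl, so no measured step shows this swap directly. The closest evidence comes from the other swaps among these three compounds. Both a 3.2-fold lower number from compound 1 to compound 2 (0.50 log units; beyond the scatter) and a 2.4-fold lower number from compound 1 to compound 3 (0.39 log units; beyond the scatter) are modest, and a 1.3-fold higher number from compound 2 to compound 3 (0.11 log units; within the scatter) stays within the scatter.

A modest step at most is therefore expected. The direction is uncertain but leans upward, as compound 3 at 9400 nM lies toward the low end of the measured span, whose top is compound 1 at 22900 nM. The estimated step is a 1.4-fold higher number from compound 3 to compound 4 (0.14 log units; within the scatter). For compound 4 the estimate is 13000 nM, with an expected range from 5500 nM to 30000 nM.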

Compound 4, half-maximal cytotoxic concentration: > 202000 nM
Compound 4: no number, only a limit (the forecaster's own chance of this, stated with the estimate: 5%); middle value at least 15-fold (1.19 log units) away from the limit.
By their numbers in this assay, from the lowest: compounds 2 and 3 (each within the scatter of the next); then compound 1. At a limit, above all of these: compound 4.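

In this assay compound 4 gives no exact number, only a limit: the limit of > 202000 nM in this assay, at which 1 of the 4 values shown sits.

Read against that limit, the swap to phenyl gives an at least 21-fold higher number from compound 3 to compound 4 (1.33 log units; beyond the scatter), and the comparisons with the other two compounds give an at least 27-fold higher number from compound 2 to compound 4 (1.44 log units; beyond the scatter) and an at least 8.8-fold higher number from compound 1 to compound 4 (0.94 log units; beyond the scatter). The earlier swaps among tert-butyl, methylsulfanyl and trifluoromethyl moved the number modestly or stayed within the scatter, so this aromatic carbon, para to a large group, turns out to allow a far bigger change than those compounds showed, and phenyl, the only ring among these four groups, sets compound 4 apart from all three.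

As far as these compounds go, these steps give only minimum sizes, so how far compound 4 truly lies past its limit stays unknown. The compounds shown also leave open whether the shift belongs to the aromatic ring itself or would also appear with another ring at this place, such as a cyclohexyl or a pyridyl group, and these four compounds alone cannot give a reason for the shift.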